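The source may hold more compounds than are shown below. What is called first, only, known or untested is meant among the compounds shown, and "the series" means these compounds.

Working notes on the series.

Compound 1 `O=C(CCCCC1CCSS1)NCc1cn(CCCOc2ccc3ccc(=O)oc3c2)nn1` is the reference point; in a functional assay on PC-12 cells (Rattus norvegicus) for cytotoxicity, read by MTT assay, with stated times of 3 h and 2 h, tested at 1 uM (a lower number here means a weaker effect, a higher number a stronger effect of the compound at the concentration tested), compound 1 gives 37.2%. Compound 2 `Cc1cc(=O)oc2cc(OCCCn3cc(CNC(=O)CCCCC4CCSS4)nn3)ccc12` differs from compound 1 only by methyl in place of hydrogen on an aromatic carbon. In this assay compound 2 gives 54.5%, and the step is a number 17.3 percentage points higher from compound 1 to compound 2 (beyond the scatter). Compound 3 `O=C(CCCCC1CCSS1)NCc1cn(CCCCCOc2ccc3ccc(=O)oc3c2)nn1` differs from compound 1 in more than one place; the difference between the two cores is not broken down here. In this assay compound 3 gives 57.2%, the highest of the three numbers, although its gap to compound 2 lies within the scatter and only its gap to compound 1 lies beyond it.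

Compound 4 `Cc1cc(=O)oc2cc(OCCCCCn3cc(CNC(=O)CCCCC4CCSS4)nn3)ccc12` has not yet been measured. Relative to compound 3 it carries methyl in place of hydrogen on an aromatic carbon, the same kind of change as that from compound 1 to compound 2, with the place described in the same words. Going by the values given here, only this one earlier instance of the change is available, so the expectation for compound 4 rests on it alone, with compound 3 as the new starting point. The step expected from compound 3 to compound 4 in this assay is a number 10.8 percentage points higher from compound 3 to compound 4 (beyond the scatter), somewhat smaller than the earlier one because compound 3 already gives 57.2%, a higher starting number than compound 1 at 37.2%. Compound 4 is therefore expected to give about 68% in this assay, with the estimate spanning from 54% to 82%.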

Compound 4, a percentage reported as activity, at one concentration (the size of the read-out at that concentration, not a potency): 56.5%
The estimate for compound 4 lay 11.5 percentage points above the measured number, and the stated range covers the measured number.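

In this assay, methyl in place of hydrogen on an aromatic carbon does not carry over from one core to the other as a fixed step: the same change on two cores in this assay, a number 17.3 percentage points higher (beyond the scatter) from compound 1 to compound 2 and a number 0.7 percentage points lower (within the scatter) from compound 3 to compound 4, 18 percentage points apart, beyond the scatter of two such steps On the core of compound 3, the change gives a number 0.7 percentage points lower from compound 3 to compound 4 (within the scatter), so no effect of the methyl can be read on that core, whereas one can be read on the core of compound 1. This pair of steps shows that, in this series, the result of the change depends on the core that carries it, but it does not show why the two steps differ or how the change would behave on any further core, and a read-out at a single concentration says nothing about potency.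

The compounds shown carry only hydrogen or methyl at this place on the ring, so it remains open how an ethyl group, a chlorine atom or a methoxy group there would read in this assay on either core. As far as these compounds go, it also remains open whether the difference between the two steps would persist with a longer chain where the core of compound 1 and the core of compound 3 differ, or with an amine or a carboxylic acid introduced elsewhere on these cores.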